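The source may report more compounds than this note shows. Statements on the series, on what has been measured and on what is new or still open speak of the compounds shown alone.

In a functional assay on PC-12 cells (Rattus norvegicus) for cytotoxicity, read by MTT assay, with stated times of 3 h and 2 h, tested at 1 uM (on this read-out higher numbers stand for a stronger effect at the one concentration tested and lower numbers for a weaker effect), the three measured compounds gave these values:

Compound 1 `CC(=O)c1cc2ccc(OCCCn3cc(CNC(=O)CCCCC4CCSS4)nn3)cc2oc1=O` gave 35.5%.
Compound 2 `CCOC(=O)c1cc2ccc(OCCCn3cc(CNC(=O)CCCCC4CCSS4)nn3)cc2oc1=O` gave 28.3%.
Compound 3 `O=C(CCCCC1CCSS1)NCc1cn(CCCOc2ccc3cc(-c4ccccc4)c(=O)oc3c2)nn1` gave 31.9%.

Compound 3 stands second highest of the three, but the gaps a number 3.6 percentage points higher from compound 2 to compound 3 (within the scatter) and a number 3.6 percentage points lower from compound 1 to compound 3 (within the scatter) are within the scatter, so no ranking can be read from them. Compound 4 `O=C(CCCCC1CCSS1)NCc1cn(CCCOc2ccc3cc(-c4ccc(Br)cc4)c(=O)oc3c2)nn1` differs from compound 3 by bromo in place of hydrogen on an aromatic carbon. Within the data shown here, no measured step involves a bromo group; the three known steps change the other end of the shared core, and each, including a number 7.2 percentage points lower from compound 1 to compound 2 (within the scatter), stayed within the scatter. The step from compound 3 to compound 4 is therefore expected to be a number 0.1 percentage points higher from compound 3 to compound 4 (within the scatter), not beyond the scatter. Compound 4 is estimated at 32%, between 20% and 45%.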

Compound 4, a percentage reported as activity, at one concentration (the size of the read-out at that concentration, not a potency): 42.8%
Beside the measured number, compound 4's estimate is 10.8 percentage points below it; the measured number falls inside the stated range.
By their numbers in this assay, from the lowest: compounds 2, 3, 1 and 4 (each within the scatter of the next, the first and the last beyond it).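

In this assay, among these compounds, a single bromo on the phenyl ring gives a number 10.9 percentage points higher from compound 3 to compound 4 (beyond the scatter), the first step to pass the scatter. Replacing the ethoxycarbonyl group with 4-bromophenyl gives a number 14.5 percentage points higher from compound 2 to compound 4 (beyond the scatter), also past the scatter, whereas replacing acetyl with it gives a number 7.3 percentage points higher from compound 1 to compound 4 (within the scatter), so compound 4 is not clearly separated from every other compound. Nothing here explains the effect of the bromo group. Still open, on these data alone, is whether a chloro, methyl or methoxy group at the same ring position would give a similar step, and whether any of these would differ from bromo.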